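The compounds below may be only part of what the source reports. "The series", "measured", "known", "first", "only" and "open" are said of these compounds alone.

Compound 1 `O=S(=O)(Nc1ccc2oc(-c3ccccc3)nc2c1)c1ccccc1Cl` gives > 100000 nM in an assay on cells for inhibition of HSP60/HSP10 (Homo sapiens), with a stated time of 60 min (on this read-out higher numbers stand for weaker inhibition and lower numbers for stronger inhibition), a limit of the assay and not a number.
Compound 2 `O=S(=O)(Nc1ccc2oc(-c3ccccc3)nc2c1)c1cccc(F)c1` gives > 100000 nM in this assay, likewise only a limit.
Compound 3 `O=S(=O)(Nc1ccc2oc(-c3ccccc3)nc2c1)c1ccccc1F` gives > 100000 nM in this assay, again only a limit.

Compound 3 therefore stands nowhere on a readable scale: all three values shown sit at the limit of > 100000 nM in this assay, at which 3 of the 3 values shown sit. The steps a step that the two limits leave unreadable from compound 1 to compound 2, a step that the two limits leave unreadable from compound 1 to compound 3 and a step that the two limits leave unreadable from compound 2 to compound 3 remain unreadable; each joins two limits, and nothing can be said about their size or direction. Compound 4 `CCc1ccc(S(=O)(=O)Nc2ccc3oc(-c4ccccc4)nc3c2)cc1` has not been measured in this assay. It differs from compound 3 by 4-ethylphenyl in place of 2-fluorophenyl on a sulfonyl sulfur. Going by the values given here, no measured step bears on this change in a readable way; the three changes of the aryl group on the sulfonyl sulfur each left the compound at the limit. No step beyond the scatter is expected for compound 4, so its expected step is a number no higher from compound 3 to compound 4 (the limit leaves the size open). For compound 4 in this assay the estimate is 100000 nM, from 30000 nM to 300000 nM, and a limit rather than a number is the expected outcome.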

Compound 4, half-maximal inhibitory concentration: > 100000 nM
Compound 4: no number, only a limit (the forecaster's own chance of this, stated with the estimate: 85%); the middle value sits exactly at the limit.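

Going by these compounds alone, no step from compound 1, compound 2 or compound 3 to compound 4 can be read, as each joins two limits: the limit of > 100000 nM in this assay, at which 4 of the 4 values shown sit.

The compounds shown leave open whether any group on the sulfonyl sulfur gives a readable number in this assay.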